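The source may hold more compounds than are shown below. What is called first, only, known or untested is meant among the compounds shown, and "the series" means these compounds.

Compound 1 `COC[C@]12C[C@H]1[C@@](C)(c1cc(NC(=O)c3ccc(Cl)cn3)cc(F)c1F)N=C(N)S2`: 13 10^-6 cm/s
Compound 2 `CN(C)C(=O)[C@]12C[C@H]1[C@@](C)(c1cc(NC(=O)c3ccc(Cl)cn3)cc(F)c1F)N=C(N)S2`: 40 10^-6 cm/s

In an ADME assay on LLC-PK1 cells (Sus scrofa) for permeability (a lower number here means that the compound crosses the layer more slowly, a higher number that the compound crosses the layer faster), compound 2 stands highest of the two, at 40 10^-6 cm/s. Compound 3 `C[C@]1(c2cc(NC(=O)c3ccc(Cl)cn3)cc(F)c2F)N=C(N)S[C@@]2(C#N)C[C@H]21` has cyano in place of dimethylcarbamoyl on a saturated ring carbon. Going by the values given here, only one measured step involves a change on that carbon, the modest 3.1-fold higher number from compound 1 to compound 2 (0.49 log units; beyond the scatter), and no cyano compound has yet been measured. A step of similar or smaller size is therefore expected, and a downward direction is tentatively favoured. The expected change is a 1.8-fold lower number from compound 2 to compound 3 (0.26 log units; within the scatter). Compound 3 is estimated at 22 10^-6 cm/s, with an expected range of 9 10^-6 cm/s to 45 10^-6 cm/s.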

Compound 3, apparent permeability: 39 10^-6 cm/s
Estimate against measurement, compound 3: 1.8-fold (0.25 log units) below, within the range that was stated.
By their numbers in this assay, from the lowest: compound 1; then compounds 3 and 2 (each within the scatter of the next).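

In this assay, cyano in place of dimethylcarbamoyl on this saturated ring carbon gives a 1.0-fold lower number from compound 2 to compound 3 (0.01 log units; within the scatter), so the two groups cannot be told apart here. Cyano in place of methoxymethyl gives a 3.0-fold higher number from compound 1 to compound 3 (0.48 log units; beyond the scatter), a step beyond the scatter, which leaves compound 1 alone below the other two. Nothing measured accounts for this. Still open, from the compounds shown here alone, is whether a carboxylic acid, an amine or a longer chain on this carbon would read with compound 1 or with compounds 2 and 3.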